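Chloro at a Second Aromatic Carbon on the Shared Core

A few compounds are considered here, and "the series" means these few. Any claim that something is new, unique, unknown or untested is made for them only; others in the source may bear on it.

For the measured compounds named here, compound 2 `Cc1nc(-c2ccccc2)sc1C(=O)CSc1nc(-c2ccccc2)c(C#N)c(=O)[nH]1` is one of three compounds measured in a functional assay on U-87MG ATCC cells for antiproliferative activity against U-87 MG (Homo sapiens), read by MTT assay, with a stated time of 48 h, tested at 10 uM (on this read-out lower numbers stand for a stronger effect and higher numbers for a weaker effect at the one concentration tested), where compound 2 gives 87.5%. Among the three numbers this is the highest, but its nearest neighbour, compound 3 `Cc1nc(-c2ccc(Cl)cc2)sc1C(=O)CSc1nc(-c2ccccc2)c(C#N)c(=O)[nH]1`, gives 83.1%, a value within the scatter of compound 2. Going by the values given here, compound 1 `COc1ccc(-c2nc(C)c(C(=O)CSc3nc(N)c(C#N)c(-c4ccc(OC)cc4)n3)s2)cc1` lies much further away and gives 28.7%; it differs from compound 2 in several places at once, so no single step links the two.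

Compound 4 `Cc1nc(-c2ccccc2)sc1C(=O)CSc1nc(-c2ccc(Cl)cc2)c(C#N)c(=O)[nH]1` differs from compound 2 by chloro in place of hydrogen on an aromatic carbon. Among the compounds with values here, one measured step bears on this change: a number 4.4 percentage points lower from compound 2 to compound 3 (within the scatter), the same kind of change, chloro in place of hydrogen on an aromatic carbon, but made at a different aromatic carbon. Since that step stayed within the scatter, the expectation for compound 4 in this assay is likewise no step beyond the scatter, the estimated change being a number 3.5 percentage points lower from compound 2 to compound 4 (within the scatter). Compound 4 is therefore expected to give about 84%, in a range from 70% to 97%.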

Compound 4, a percentage reported as activity, at one concentration (the size of the read-out at that concentration, not a potency): 85.2%
Estimate against measurement, compound 4: 1.2 percentage points below, and the stated range covers the measured number.
By their numbers in this assay, from the lowest: compound 1; then compounds 3, 4 and 2 (each within the scatter of the next).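

Applied at a different aromatic carbon, the same change, phenyl to 4-chlorophenyl, gives in this assay a number 2.3 percentage points lower from compound 2 to compound 4 (within the scatter) as its step. The earlier compounds shown here showed the chloro step at only one place, whereas it has now stayed within the scatter at two places on the shared core, so neither placement separates a chloro compound from compound 2 on this read-out. No measurement is available that would account for this result.

On these data alone, it remains open whether a different group at this para place, such as a carboxylic acid or a longer alkyl chain, would move the number beyond the scatter. Compound 1 gives 28.7% but differs from compound 2 in several places at once, so which of those differences matters cannot be told from these compounds.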